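A few compounds are considered here, and "the series" means these few. Any claim that something is new, unique, unknown or untested is made for them only; others in the source may bear on it.

Working notes on the series. In an ADME assay on Vero cells (Chlorocebus sabaeus) for cytotoxicity, read by neutral red uptake, tested at 25 ug/mL (a higher number here means a weaker effect of the compound at the concentration tested, a lower number a stronger effect), compound 1 `O=C1CSC(c2c(Cl)cccc2Cl)N1CCN1CCCCC1` gives 100%. In this assay compound 2 `COc1ccc(C2SCC(=O)N2CCN2CCCCC2)cc1` gives 100%, and in this assay compound 3 `O=C1CSC(c2cccc(Cl)c2)N1CCN1CCCCC1` gives 100%. Compound 3 therefore stands level with compound 1 and compound 2 at the digits recorded; its gaps to both lie within the usual scatter of the method, so no order among the three can be read from these numbers.

The next compound, compound 4 `O=C1CSC(c2cccc(O)c2)N1CCN1CCCCC1`, has not yet been tested in this assay. It differs from compound 3 in one place: hydroxy in place of chloro on an aromatic carbon. For the measured compounds named here, no step between two measured compounds is available to gauge such a change, and the three measured values show no spread from which a trend could be taken. Going by the values given here, the only anchor is compound 3 with 100% in this assay, and nothing in the measured set points in either direction.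

On that basis the step of no change at the digits printed from compound 3 to compound 4 (within the scatter) is expected to stay within the scatter, with no direction beyond it. Compound 4 is estimated at 100% in this assay, with a range from 85% to 100%.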

Compound 4, a percentage reported as activity, at one concentration (the size of the read-out at that concentration, not a potency): 100%
Compound 4: the middle estimate sits on the measured number at the digits printed; the measured number falls inside the stated range.
By their numbers in this assay, from the lowest: compounds 1, 2, 3 and 4 (each within the scatter of the next).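

In this assay, for the compounds shown here, the exchange of 3-chlorophenyl for 3-hydroxyphenyl gives no change at the digits printed from compound 3 to compound 4 (within the scatter) and is the only step between two measured compounds that differ in one place. Going by these compounds alone, at this one position, on this pair and at this one tested concentration, hydroxy in place of chloro, with one hydrogen-bond donor and one hydrogen-bond acceptor entering, thus leaves the read-out level, which the earlier compounds could not show because none of them formed such a pair. Nothing measured alongside these values speaks to why the read-out stays level.

On these data alone, whether an amine or a carboxylic acid on this aromatic carbon would read level with compound 3 and compound 4 stays open, as does the reading of a longer chain such as an ethoxy group there. With all four compounds level at the digits printed, the compounds shown also leave open which change anywhere in the series, if any, would lower the read-out.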